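A few compounds are considered here, and "the series" means these few. Any claim that something is new, unique, unknown or untested is made for them only; others in the source may bear on it.

Measured compounds:
compound 1, `CCCCCCCCCNC(=O)N(Cc1cc(OC)ccc1OC)n1cnnc1`: > 50000 nM
compound 2, `N#Cc1ccc(CN(C(=O)Nc2cc(C(F)(F)F)cc(C(F)(F)F)c2)n2cnnc2)cc1`: 9390 nM

In a functional assay on A549 cells (Homo sapiens) for cytotoxicity, read by MTT assay, with a stated time of 48 h (a lower number here means a stronger inhibitor, a higher number a weaker inhibitor), compound 1 gives > 50000 nM, which is a limit of the assay and not a number. Compound 1 therefore stands at the limit of > 50000 nM in this assay, at which 1 of the 2 values shown sits, so its true potency is not known beyond that. In this assay compound 2 gives 9390 nM, a measured number for an aryl urea of the same core. Compound 3, `COc1ccc(OC)c(CN(C(=O)Nc2ccc(C)cc2)n2cnnc2)c1`, has not yet been measured. It differs from compound 1 in one place: 4-methylphenyl in place of nonyl on an amide-type nitrogen. With compound 1 known only as a limit, the size of the step from compound 1 to compound 3 in this assay can only be expected, not measured; the aryl urea compound 2 gives a measured value, so a step toward measurable potency, from compound 1 to compound 3, is expected at an at least 1.6-fold lower number from compound 1 to compound 3 (0.22 log units; that floor lies within the scatter). Compound 3 is estimated at 30000 nM, with a range of 8000 nM to 100000 nM, and a real chance that only a limit is reported again.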

Compound 3, half-maximal inhibitory concentration: 17400 nM
Compound 3: the middle estimate sits 1.7-fold (0.24 log units) above what was measured; the range from low to high includes it.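

In this assay, going by these compounds alone, placing 4-methylphenyl in place of nonyl on the amide-type nitrogen gives the first readable step at this position: an at least 2.8-fold lower number from compound 1 to compound 3 (0.45 log units; beyond the scatter) lies beyond the scatter. The earlier compounds shown here offered no such reading, as compound 2 differs from compound 1 in more than one place. Compound 1 remains a limit of the assay and not a number, so this change has a lower bound on its size but no measured size: the limit of > 50000 nM in this assay, at which 1 of the 3 values shown sits.

The compounds shown leave open how large the step from nonyl really is, and whether a plain phenyl or a shorter chain such as butyl on that nitrogen would behave like 4-methylphenyl. They also leave open what an amine or a carboxylic acid on the aromatic ring would do to the number.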